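A few compounds are considered here, and "the series" means these few. Any claim that something is new, unique, unknown or untested is made for them only; others in the source may bear on it.

Series notes. Compound 1 `CCN(CC)Cc1ccc2nc(NC(=O)N/N=C(\C)c3ccccn3)sc2c1` carries a pyridin-2-yl group on a carbon with a double bond to nitrogen; in a functional assay on U-937 cells (Homo sapiens) for antiproliferative activity, read by CCK-8 assay, with a stated time of 24 h (on this read-out lower numbers stand for stronger inhibition and higher numbers for weaker inhibition), compound 1 gives 15600 nM. Compound 2 `CCN(CC)Cc1ccc2nc(NC(=O)N/N=C(\C)c3cnccn3)sc2c1` differs by pyrazin-2-yl in place of pyridin-2-yl on a carbon with a double bond to nitrogen. In this assay compound 2 reaches only the limit of the assay, > 40000 nM. The step is an at least 2.5-fold higher number from compound 1 to compound 2 (0.40 log units; beyond the scatter), and its true size can be read only against (the limit of > 40000 nM in this assay, at which 2 of the 3 values shown sit). Compound 3 `C/C(=N\NC(=O)Nc1ccc(CN2CCC(C)CC2)cc1)c1ccccn1` is built on another core; the difference between the two cores is not broken down here. In this assay compound 3 also sits at the limit of the assay, > 40000 nM. Compound 4 `C/C(=N\NC(=O)Nc1ccc(CN2CCC(C)CC2)cc1)c1cnccn1` is not yet measured and stands to compound 3 as compound 2 stands to compound 1: pyrazin-2-yl in place of pyridin-2-yl on a carbon with a double bond to nitrogen, the same change at the same place. The step from compound 3 to compound 4 is expected to be a step that the limit leaves unreadable from compound 3 to compound 4, an expectation that rests on compound 3 already giving > 40000 nM and on the direction of an at least 2.5-fold higher number from compound 1 to compound 2 (0.40 log units; beyond the scatter). For compound 4 in this assay the estimated value is 70000 nM, most probably reported again only as a limit.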

Compound 4, half-maximal inhibitory concentration: > 40000 nM
Compound 4: only a limit was reported; the forecaster's own chance of this, stated with the estimate: 90%; the middle value does not contradict the limit.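

In this assay compound 4 gives > 40000 nM, which is a limit of the assay. Compound 3 also sits at a limit, so no step between compound 3 and compound 4 can be read: the limit of > 40000 nM in this assay, at which 3 of the 4 values shown sit.

Still open, from the compounds shown here alone, is whether pyrazin-2-yl in place of pyridin-2-yl raises the number on the core of compound 3, as it does on the core of compound 1.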